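The source may hold more compounds than are shown below. What is called first, only, known or untested is meant among the compounds shown, and "the series" means these compounds.

Working notes on the series. Compound 2 `Cc1ncnc2c1c(-c1ccoc1)cn2[C@@H]1O[C@H](CO)[C@@H](O)[C@H]1O` carries furan-3-yl on the shared core. In a functional assay on HCT-116 cells (Homo sapiens), read by MTT assay, with a stated time of 72 h (a higher number here means a weaker inhibitor, a lower number a stronger inhibitor), compound 2 reads > 20000 nM as a limit of the assay and not a number. Compound 1 `CSc1ncnc2c1c(-c1ccsc1)cn2[C@@H]1O[C@H](CO)[C@@H](O)[C@H]1O` reads > 20000 nM in this assay and this too is a limit. Among the measured compounds shown here, compound 2 thus stands at the limit of > 20000 nM in this assay, at which 2 of the 2 values shown sit, and no order can be drawn so far.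

Compound 3 `Cc1ncnc2c1c(-c1ccsc1)cn2[C@@H]1O[C@H](CO)[C@@H](O)[C@H]1O` has thiophen-3-yl in place of furan-3-yl on an aromatic carbon of the five-membered aromatic ring, and the count for this swap is thiophen-3-yl in place of furan-3-yl on an aromatic carbon with nothing else altered. For the measured compounds named here, no measured step gives a size for this change. With compound 2 reading > 20000 nM as a limit, the expectation in this assay is for no change beyond the scatter and no clear direction. The estimated step of a number no higher from compound 2 to compound 3 (the limit leaves the size open) is expected to be small. For compound 3 the expected value is 20000 nM with an estimated range of 6000 nM to 40000 nM and a report as a limit is the likeliest outcome.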

Compound 3, half-maximal inhibitory concentration: 460 nM
Beside the measured number, compound 3's estimate is 43-fold (1.64 log units) above it, and the stated range ends above it.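

In this assay, thiophen-3-yl in place of furan-3-yl on this aromatic carbon gives an at least 43-fold lower number from compound 2 to compound 3 (1.63 log units; beyond the scatter), so this place on the shared core responds strongly to a swap of the ring oxygen for sulfur at an unchanged count of heavy atoms. Thiophen-3-yl alone does not account for the reading: with it held fixed, methyl in place of methylsulfanyl on an aromatic carbon gives an at least 43-fold lower number from compound 1 to compound 3 (1.63 log units; beyond the scatter), so of the three compounds only the pairing of methyl with thiophen-3-yl gives a reading that is a number. Both steps remain open in size, since each starts from a limit of the assay and not a number: the limit of > 20000 nM in this assay, at which 2 of the 3 values shown sit.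

Whether the reading of compound 3 depends on a sulfur-bearing ring at this carbon remains open, as the compounds shown include neither phenyl nor thiophen-2-yl there. Also open, going by these compounds, is how far the other place tolerates change, for instance an amine or an ethyl chain in place of methyl.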